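Longer chain on the triple-bonded carbon, second core

This account rests on a few compounds, and the source may have more. Where it says the series, first, only, none or still open, it means among the compounds named here.

Compound 1 `CCN(CC)CCNC(=O)C1CC(C(CC)(CC)c2ccc(C#CC(C)(O)CC)c(C)c2)=CN1CC` and compound 2 `CCCC(O)(C#Cc1ccc(C(CC)(CC)C2=CN(CC)C(C(=O)NCCN(CC)CC)C2)cc1C)CCC` share one core. In an assay on isolated protein for binding affinity to vitamin D3 receptor (Homo sapiens), read by fluorescence polarization, tested at 1 uM (a higher number here means more inhibition at the concentration tested (going by the name of the read-out), a lower number less inhibition), compound 1 gives 59.2% and compound 2 gives 51.1%. The change between them is a group of 8 heavy atoms (7 carbon, 1 oxygen; no ring) in place of a group of 5 heavy atoms (4 carbon, 1 oxygen; no ring), on a triple-bonded carbon, and it made a step of a number 8.1 percentage points lower from compound 1 to compound 2 (within the scatter). Compound 3 `CCN(CC)CCNC(=O)C1CC=C(C(CC)(CC)c2ccc(C#CC(C)(O)CC)c(C)c2)N1CC` has the same atoms as compound 1 joined differently; the difference between the two cores is not broken down here. In this assay compound 3 gives 63.4%, which against compound 1 lies within the scatter, while against compound 2 the gap is beyond it. Compound 4 `CCCC(O)(C#Cc1ccc(C(CC)(CC)C2=CCC(C(=O)NCCN(CC)CC)N2CC)cc1C)CCC` has not yet been measured in this assay. It stands to compound 3 as compound 2 stands to compound 1: the change is a group of 8 heavy atoms (7 carbon, 1 oxygen; no ring) in place of a group of 5 heavy atoms (4 carbon, 1 oxygen; no ring), on a triple-bonded carbon, the same change at the same place, seen so far only once among these compounds. The step from compound 3 to compound 4 is expected to be about a number 8.4 percentage points lower from compound 3 to compound 4 (within the scatter), resting on the step of a number 8.1 percentage points lower from compound 1 to compound 2 (within the scatter) on the core of compound 1. Compound 4 is therefore estimated at 55%, with the range 44% to 66% allowing for a single precedent.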

Compound 4, a percentage reported as inhibition, at one concentration (the size of the read-out at that concentration, not a potency): 52.1%
Compound 4: middle estimate off by 2.9 percentage points, on the high side; low and high end bracket the measured number.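

In this assay, placing the group of 8 heavy atoms on the triple-bonded carbon in place of 1-hydroxy-1-methylpropyl gives a step of a number 11.3 percentage points lower from compound 3 to compound 4 (beyond the scatter). Set beside the step on the core of compound 1, this step does not stand apart, so on these two pairs the change carries from one core to the other with no detectable difference: the same change on two cores in this assay, a number 8.1 percentage points lower (within the scatter) from compound 1 to compound 2 and a number 11.3 percentage points lower (beyond the scatter) from compound 3 to compound 4, 3.2 percentage points apart, within the scatter of two such steps

Going by these compounds alone, this rests on only two pairs, a single read-out at one concentration and two cores, and only the step on the core of compound 3 lies beyond the scatter, so it does not establish a real drop on the core of compound 1 or a rule for other cores.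

The compounds shown leave open how a longer chain, an amine or a carboxylic acid would fare on the triple-bonded carbon in place of 1-hydroxy-1-methylpropyl. Also open, from the compounds shown here alone, is whether a step of this size would hold on a third core, or at another concentration.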